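Benzyl replacement on a shared core: compound 3 to compound 4

The compounds below may be only part of what the source reports. "The series", "measured", "known", "first", "only" and "open" are said of these compounds alone.

Compound 1 `CCOc1cc(C2CCN(C)CC2)ccc1Nc1ncc2c(n1)N(Cc1ccccc1Br)[C@H](CC)C(=O)N2C` — "not determined" (no result reported)
Compound 2 `CCOc1cc(C2CCN(C)CC2)ccc1Nc1ncc2c(n1)N(Cc1ccc(Br)cc1)[C@H](CC)C(=O)N2C` — "not determined" (no result reported)
Compound 3 `CCOc1cc(C2CCN(C)CC2)ccc1Nc1ncc2c(n1)N(Cc1cccc(C#N)c1)[C@H](CC)C(=O)N2C` — 1800 nM

Three compounds share one core and differ only in the group on the saturated chain carbon bound to a nitrogen on an aromatic ring in a ring. Within the data shown here, in an assay on isolated protein for inhibition of serine/threonine-protein kinase PLK1 (Homo sapiens), read by Z'-LYTE, with a stated time of 60 min (on this read-out higher numbers stand for weaker inhibition and lower numbers for stronger inhibition), compound 3 gives 1800 nM, the only number in the set; for compound 1 and compound 2 no result is reported. Compound 4 `CCOc1cc(C2CCN(C)CC2)ccc1Nc1ncc2c(n1)N(Cc1sccc1C)[C@H](CC)C(=O)N2C` carries 3-methylthiophen-2-yl in place of 3-cyanophenyl on a saturated chain carbon bound to a nitrogen on an aromatic ring in a ring. Among the measured compounds shown here, no measured pair shows how this position responds, so the expectation rests on compound 3 alone. The step from compound 3 to compound 4 is expected to stay within the usual scatter, a 1.1-fold higher number from compound 3 to compound 4 (0.05 log units; within the scatter). Compound 4 is estimated at 2000 nM in this assay, with a range from 700 nM to 6000 nM.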

Compound 4, half-maximal inhibitory concentration: 68 nM
Beside the measured number, compound 4's estimate is 29-fold (1.47 log units) above it, and the stated range ends above it.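

In this assay, the position on a saturated chain carbon bound to a nitrogen on an aromatic ring in a ring proves responsive: 3-methylthiophen-2-yl in place of 3-cyanophenyl gives a 26-fold lower number from compound 3 to compound 4 (1.42 log units; beyond the scatter). This only measured pair shows that exchanging the group at this position can move the number well beyond the scatter. Nothing available explains this step. Steps involving compound 1 and compound 2 cannot be read. The compounds shown leave open whether the methyl group matters, and how a plain thiophen-2-yl or an amine-bearing benzyl would compare.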